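This account rests on a few compounds, and the source may have more. Where it says the series, first, only, none or still open, it means among the compounds named here.

For the measured compounds named here, in a toxicity assay on Vero cells (Chlorocebus sabaeus) for cytotoxicity, read by MTT assay (a lower number here means a stronger inhibitor, a higher number a weaker inhibitor), compound 1 (`COC(=O)NC(=O)c1ccsc1NC(=O)c1ccc(S(=O)(=O)N2CCC(C)CC2)cc1`) gives 9.13 ug/mL and compound 2 (`CCCCNS(=O)(=O)c1ccc(C(=O)Nc2sccc2C(=O)NC(=O)OC)cc1`) gives 29.5 ug/mL, so compound 2 holds the higher of the two numbers so far. Compound 3 (`COC(=O)NC(=O)c1ccsc1NC(=O)c1ccc(S(=O)(=O)N(C)C)cc1`) is not yet measured. It has dimethylamino in place of butylamino on a sulfonyl sulfur. Going by the values given here, only one measured step bears on this change: a 3.2-fold higher number from compound 1 to compound 2 (0.51 log units; beyond the scatter), a modest step beyond the scatter that also exchanges the group on the sulfonyl sulfur. Read in reverse, it shows that replacing butylamino with 4-methylpiperidin-1-yl gives a lower number, but a single step with a different incoming group is thin support. In this assay, the expected change is small and toward a lower number, within the scatter: a 1.5-fold lower number from compound 2 to compound 3 (0.17 log units; within the scatter). For compound 3 the estimated value is 20 ug/mL, with an expected range of 7 ug/mL to 55 ug/mL.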

Compound 3, half-maximal inhibitory concentration: 16.2 ug/mL
For compound 3 the middle estimate is 1.2-fold (0.09 log units) above the measured one; the measured number falls inside the stated range.
By their numbers in this assay, from the lowest: compounds 1, 3 and 2 (each within the scatter of the next, the first and the last beyond it).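

In this assay the exchange of butylamino for dimethylamino on a sulfonyl sulfur, which also removes the hydrogen-bond donor counted for butylamino, gives no step beyond the scatter (a 1.8-fold lower number from compound 2 to compound 3 (0.26 log units; within the scatter)). The exchange of 4-methylpiperidin-1-yl for dimethylamino is likewise within the scatter (a 1.8-fold higher number from compound 1 to compound 3 (0.25 log units; within the scatter)), so compound 3 cannot be separated from either compound 1 or compound 2, although those two remain beyond the scatter of each other. No measured evidence accounts for these values.

Going by these compounds, how an unsubstituted amino group, a morpholin-4-yl group or a longer chain on the sulfonyl sulfur would read remains open. The compounds shown vary only this group, so the effect of replacing the methyl carbamate elsewhere on the shared core also remains open.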